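Cyclopropyl to cyclohexyl on the amide nitrogen

This account rests on a few compounds, and the source may have more. Where it says the series, first, only, none or still open, it means among the compounds named here.

Compound 2 `Nc1sc(-c2ccc(Br)cc2)c(-c2ccc(Cl)cc2)c1C(=O)NC1CC1` gives 37300 nM in a functional assay on PC-3 cells (Homo sapiens) for cytotoxicity, read by sulforhodamine B assay, with a stated time of 72 h (a lower number here means a stronger inhibitor, a higher number a weaker inhibitor), the highest of the two numbers measured; compound 1 `Nc1sc(-c2ccc(Cl)cc2)c(-c2ccc(Cl)cc2)c1C(=O)NC1CCCCC1` gives 7300 nM in this assay, a lower number beyond the scatter. Compound 3 `Nc1sc(-c2ccc(Br)cc2)c(-c2ccc(Cl)cc2)c1C(=O)NC1CCCCC1` carries cyclohexyl in place of cyclopropyl on an amide-type nitrogen, so it shares its amide substituent with compound 1 while keeping the rest of compound 2. Going by the values given here, no single-change step between measured compounds exists; a moderate step toward a lower number is expected because compound 1 with the same cyclohexyl gives 7300 nM. Compound 3 is expected to give 9000 nM, range 3000 nM to 27000 nM, an expected step of a 4.1-fold lower number from compound 2 to compound 3 (0.62 log units; beyond the scatter).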

Compound 3, half-maximal inhibitory concentration: 28400 nM
For compound 3 the middle estimate is 3.2-fold (0.50 log units) below the measured one, and the stated range ends below it.
By their numbers in this assay, from the lowest: compound 1; then compounds 3 and 2 (each within the scatter of the next).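

In this assay, with bromo held in place, cyclohexyl in place of cyclopropyl on the amide-type nitrogen gives a 1.3-fold lower number from compound 2 to compound 3 (0.12 log units; within the scatter), so this pair shows no readable dependence on ring size at this position. The step that lies beyond the scatter belongs to the other site, where bromo in place of chloro on an aromatic carbon gives a 3.9-fold higher number from compound 1 to compound 3 (0.59 log units; beyond the scatter). Nothing at hand bears on the cause of either step.

Open, on these data alone, is whether the cyclopropyl-to-cyclohexyl step stays as small with chloro on that aromatic carbon. Also open, as far as these compounds go, is how an amine or a longer alkyl chain on the amide nitrogen would read against cyclohexyl.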